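Benzyloxy added to the acid-bearing ring of compound 3

The source may hold more compounds than are shown below. What is called first, only, known or untested is meant among the compounds shown, and "the series" means these compounds.

Three compounds of the shared core have numbers in an ADME assay for permeability, using PAMPA, in phosphate buffer, with a stated time of 18 h, at pH 7.4; a lower number here means that the compound crosses the layer more slowly, a higher number that the compound crosses the layer faster. Compound 1 `COC(=O)c1cccc(-c2ccc(NC(=O)n3nc(Nc4ccc(S(N)(=O)=O)cc4)nc3N)cc2)c1` gives 0.09 10^-6 cm/s. Compound 2 `CNC(=O)c1ccc(Nc2nc(N)n(C(=O)Nc3ccc(-c4ccc(OCc5ccccc5)c(C(=O)O)c4)cc3)n2)cc1` gives 0.24 10^-6 cm/s. Compound 3 `Nc1nc(Nc2ccc(S(N)(=O)=O)cc2)nn1C(=O)Nc1ccc(-c2cccc(C(=O)O)c2)cc1` gives 0.015 10^-6 cm/s, the lowest of the three. Going by the values given here, the one single-point step known, a 6.0-fold lower number from compound 1 to compound 3 (0.78 log units; beyond the scatter), joins compound 3 to its nearest neighbour; compound 2 is the furthest, and its number stands well above that of compound 3, but the two differ in more than one place, so no single step links them.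

Compound 4 `Nc1nc(Nc2ccc(S(N)(=O)=O)cc2)nn1C(=O)Nc1ccc(-c2cc(OCc3ccccc3)cc(C(=O)O)c2)cc1` carries the change (benzyloxy in place of hydrogen on an aromatic carbon). Among the compounds with values here, no measured step adds this group on its own; the only step known, from compound 1 to compound 3, concerns the carboxy group and does not bear on a benzyloxy group. Within the data shown here, compound 2 is the only other compound with a benzyloxy group, and its value sits far above that of compound 3, which gives a weak hint upward. The step in this assay is therefore expected to be a 2.7-fold higher number from compound 3 to compound 4 (0.43 log units; beyond the scatter), upward, but uncertain. Compound 4 is expected to give 0.04 10^-6 cm/s, with a range of 0.01 10^-6 cm/s to 0.15 10^-6 cm/s.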

Compound 4, apparent permeability: 1.15 10^-6 cm/s
Compound 4: the middle estimate sits 29-fold (1.46 log units) below what was measured, and the stated range ends below it.
By their numbers in this assay, from the lowest: compound 3; then compound 1; then compound 2; then compound 4.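

In this assay, benzyloxy in place of hydrogen on an aromatic carbon, meta to a carboxy group, gives a 77-fold higher number from compound 3 to compound 4 (1.88 log units; beyond the scatter) and makes this position the one with the largest single-place change seen so far in the series. That step is larger than a 6.0-fold lower number from compound 1 to compound 3 (0.78 log units; beyond the scatter) and runs the other way, and the carboxy group stays in place throughout it, so a free carboxy group does not by itself hold the number at the low end of the series. Going by these compounds alone, nothing measured in this set explains why one added group moves the number so far.

Going by these compounds, it remains open whether methoxy, or a phenyl ring without the oxygen, on this same aromatic carbon would move the number as far as benzyloxy does, or whether the full benzyloxy group is needed. On these data alone, it is also open whether benzyloxy at this place gives a step of similar size and direction when the carboxy group is replaced by its methyl ester, as carried by compound 1, or by an amine.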